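The source may report more compounds than this note shows. Statements on the series, on what has been measured and on what is new or still open speak of the compounds shown alone.

The compounds here share one core, a benzamide carrying an amino group on the aniline ring, joined through a sulfur-linked chain to a thiocarbonyl that bears a nitrogen ring. Compound 1 `Nc1ccccc1NC(=O)c1ccc(CSC(=S)N2CCN(c3ccccc3)CC2)cc1` carries a phenylpiperazine on that thiocarbonyl; in a functional assay on HeLa cells (Homo sapiens) for antiproliferative activity, read by CCK-8 assay, with a stated time of 72 h (a lower number here means a stronger inhibitor, a higher number a weaker inhibitor), compound 1 gives 840 nM. Compound 2 `Nc1ccccc1NC(=O)c1ccc(CSC(=S)N2CCc3ccccc32)cc1` carries a plain indoline instead, and in this assay compound 2 gives 3450 nM, which is weaker than compound 1 by more than the usual scatter. Compound 3 `Nc1ccccc1NC(=O)c1ccc(CSC(=S)N2CCc3cc(Cl)ccc32)cc1` carries a 5-chloro-2,3-dihydro-1H-indol-1-yl, yet for compound 3 the entry in this assay reads "not determined" (no result reported), so there is no number to place it against the other two.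

The step to compound 4 `CC1CCCCN1C(=S)SCc1ccc(C(=O)Nc2ccccc2N)cc1` changes the thiocarbonyl substituent once more: 2-methylpiperidin-1-yl in place of 5-chloro-2,3-dihydro-1H-indol-1-yl on a thiocarbonyl carbon. Since compound 3 has no value, the size of this step cannot be computed, and compound 4 can only be judged against compound 1 and compound 2. A small saturated ring on the thiocarbonyl has no direct precedent among these three, so the expectation rests on the spread already seen in this assay.

Compound 4 is expected to give about 2000 nM, with a likely range from 700 nM to 6000 nM.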

Compound 4, half-maximal inhibitory concentration: 2300 nM
Compound 4: middle estimate off by 1.2-fold (0.06 log units), on the low side; measured number inside the range.
By their numbers in this assay, from the lowest: compound 1; then compounds 4 and 2 (each within the scatter of the next).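

In this assay, placing 2-methylpiperidin-1-yl instead of 2,3-dihydro-1H-indol-1-yl on the thiocarbonyl carbon gives a 1.5-fold lower number from compound 2 to compound 4 (0.18 log units; within the scatter), so these two groups cannot be told apart here. For this pair, a single six-membered non-aromatic ring does as well as a five-membered non-aromatic ring paired with a six-membered aromatic ring, which shows that an aromatic ring in this group is not needed to reach this level of activity. The printed values still leave a gap to the phenylpiperazine, as compound 1 gives 840 nM and compound 4 gives 2300 nM, and no measurement at hand offers a reason for either result.

Steps involving compound 3 cannot be read, so the compounds shown say nothing about the chlorine on the 5-chloro-2,3-dihydro-1H-indol-1-yl group. They also leave open what the methyl on the piperidine ring contributes, and whether a plain piperidine, a morpholine or a piperazine without the phenyl would stay near compound 4 or come closer to compound 1.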